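Piperidin-1-yl in place of dimethylamino on compound 2

This account rests on a few compounds, and the source may have more. Where it says the series, first, only, none or still open, it means among the compounds named here.

Of the compounds shown here, two have been read so far, compound 1 `CN1CCN(c2nc(Cl)nc3c2ncn3CCNc2ccnc3cc(Cl)ccc23)CC1` and compound 2 `CN(C)c1nc(Cl)nc2c1ncn2CCCNc1ccnc2cc(Cl)ccc12`. In an ADME assay on Vero cells (Chlorocebus sabaeus) for cytotoxicity, read by neutral red uptake, with a stated time of 48 h (on this read-out higher numbers stand for weaker inhibition and lower numbers for stronger inhibition), compound 1 gives > 10400 nM, which is a limit. In this assay compound 2 gives > 11400 nM, which is also a limit, and no numerical value is available for it.

Compound 3 `Clc1ccc2c(NCCCn3cnc4c(N5CCCCC5)nc(Cl)nc43)ccnc2c1` has not yet been measured. It differs from compound 2 by one change, piperidin-1-yl in place of dimethylamino on an aromatic carbon.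

Within the data shown here, no step between measured compounds is available to size this change. In this assay no shift beyond the usual scatter is expected, in either direction. The expected step is an at least 1.0-fold lower number from compound 2 to compound 3 (0.03 log units; that floor lies within the scatter). For compound 3 the estimated value is 10500 nM, with an expected range of 4000 nM to 25000 nM.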

Compound 3, half-maximal inhibitory concentration: > 10400 nM
Compound 3: only a limit was reported; the forecaster's own chance of this, stated with the estimate: 65%; the middle value lies beyond the limit too.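

Compound 2 and compound 3 are both reported only as limits in this assay, so no step can be read between them for piperidin-1-yl in place of dimethylamino. The compounds shown leave open whether any substitution on the shared core gives a numerical value in this assay.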